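Changing the Benzyl Ring: Expected Liver Clearance

This account rests on a few compounds, and the source may have more. Where it says the series, first, only, none or still open, it means among the compounds named here.

Measured compounds:
Compound 1, `CCNc1[nH]c(=O)n(O)c(=O)c1C(=O)NCc1ccccc1`: in an ADME assay on microsomes from liver (Homo sapiens) for metabolic stability (a lower number here means slower removal, a higher number faster removal of the compound), compound 1 gives < 0.1 uL/min, which is a limit of the assay.
Compound 2, `CCNc1[nH]c(=O)n(O)c(=O)c1C(=O)NCc1cccc(Cl)c1F`: in this assay compound 2 gives < 0.1 uL/min, also a limit of the assay.

Compound 2 therefore stands at the assay limit rather than at a number. For the measured compounds named here, the only related step, a step that the two limits leave unreadable from compound 1 to compound 2, cannot be sized because of the limit of < 0.1 uL/min in this assay, at which 2 of the 2 values shown sit. Compound 3, `CCNc1[nH]c(=O)n(O)c(=O)c1C(=O)NCc1ccc(F)cc1`, differs from compound 2 by 4-fluorophenyl in place of 3-chloro-2-fluorophenyl on a saturated chain carbon bound to an amide-type nitrogen. With no readable step to draw on, no change beyond the scatter is expected in either direction. Compound 3 is expected to stay at the limit, estimated at 0.05 uL/min with a range of 0.01 uL/min to 0.15 uL/min. The expected step is a step that the limit leaves unreadable from compound 2 to compound 3.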

Compound 3, intrinsic clearance in a liver preparation (reported as CLH), per the amount of preparation that the assay uses in the Homo sapiens assay: < 0.1 uL/min
Compound 3 was reported as a limit; the forecaster's own chance of this, stated with the estimate: 85%; the middle value lies beyond the limit too.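

No step can be read among compound 1, compound 2 and compound 3, because all three sit at a limit: the limit of < 0.1 uL/min in the Homo sapiens assay, at which 3 of the 3 values shown sit.

In a physicochemical assay for pharmacokinetics (a higher number here means that the compound lasts longer, a lower number that the compound disappears faster), compound 2 gives > 24 h, a limit of the assay. In the physicochemical assay compound 3 gives > 24 h, also a limit.

The compounds shown leave open how far these ring changes move clearance or half-life, if at all.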